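This account rests on a few compounds, and the source may have more. Where it says the series, first, only, none or still open, it means among the compounds named here.

Measured in a functional assay on HCT-116 cells (Homo sapiens) for inhibition, read by MTT assay, with a stated time of 72 h; on this read-out higher numbers stand for weaker inhibition and lower numbers for stronger inhibition:
- Compound 1 `CC1=NN(c2ccccc2)C(=O)[C@@]12C(=O)C=CC[C@@H]2c1ccc(C)cc1`: 5220 nM
- Compound 2 `CC1=NN(c2ccc(C)cc2)C(=O)[C@@]12C(=O)C=CC[C@H]2c1ccc(C)cc1`: 3620 nM

In this assay, compound 2 at 3620 nM sits within the scatter of compound 1 at 5220 nM. Compound 3 `CC1=NN(c2ccc(C)cc2)C(=O)[C@@]12C(=O)C=CC[C@@H]2c1ccc(C)cc1` is its stereoisomer: the two compounds have the same atoms and bonds and differ only in configuration as drawn: 1 of 2 stereo elements differ; a stereocentre at a saturated ring carbon is drawn S in compound 2 and R in compound 3. A stereocentre at a saturated ring carbon is drawn S in compound 2 and R in compound 3. Going by the values given here, no measured pair shows the size of such a change, so only a modest step of uncertain direction is expected, perhaps none beyond the scatter. The estimated step is a 1.2-fold higher number from compound 2 to compound 3 (0.09 log units; within the scatter). Compound 3 is expected at 4500 nM, within an estimated range of 1800 nM to 12000 nM.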

Compound 3, half-maximal inhibitory concentration: 4150 nM
Estimate against measurement, compound 3: 1.1-fold (0.04 log units) above, within the range that was stated.
By their numbers in this assay, from the lowest: compounds 2, 3 and 1 (each within the scatter of the next).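

In this assay, a stereocentre at a saturated ring carbon drawn R rather than S gives a 1.1-fold higher number from compound 2 to compound 3 (0.06 log units; within the scatter), the first measured size for such a change in this series. That comparison isolates a single element: the fact that compounds 2 and 3 differ only in the configuration as drawn. Methyl in place of hydrogen on an aromatic carbon gives a 1.3-fold lower number from compound 1 to compound 3 (0.10 log units; within the scatter), so neither change moves the number beyond the scatter. Still open, going by these compounds, is whether an amine or a carboxylic acid on that aromatic carbon, or a longer chain in place of the methyl, would do so. On these data alone, the effect of changing the other stereo element also remains open.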